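Swapping an Anilino Group for a Hydroxybutyl Chain

A few compounds are considered here, and "the series" means these few. Any claim that something is new, unique, unknown or untested is made for them only; others in the source may bear on it.

Of the compounds shown here, three have so far been tested in an assay on CHO cells for displacement of a labelled ligand from adenosine receptor A1 (Homo sapiens), read by scintillation counting, with a stated time of 1 h, tested at 1 uM; a higher number here means more inhibition at the concentration tested (going by the name of the read-out), a lower number less inhibition. Compound 1 `Nc1ncc(-c2ccc(C(F)(F)F)cc2)c(-c2ccccc2)n1` gives 51% in this assay. Compound 2 `Nc1ncc(-c2ccncc2)c(-c2ccccc2)n1` reaches only the limit of this assay, > 80%, so no number is known for it; (the limit of > 80% in this assay, at which 1 of the 3 values shown sits). Compound 3 `Clc1cccc(-c2cnc(Nc3ccccc3)nc2-c2ccccc2)c1` gives 34%, the lowest of the two numbers, sitting below compound 1 by a gap beyond the usual scatter. The next compound, compound 4 `OCCCCNc1ncc(-c2cccc(Cl)c2)c(-c2ccccc2)n1`, has not yet been measured. It differs from compound 3 in one place: 4-hydroxybutyl in place of phenyl on a nitrogen on an aromatic ring. For the measured compounds named here, no pair of measured compounds shows a change of this kind, so its effect is unknown. A step of modest size in either direction is expected, and compound 4 is estimated at 40%, within 15% to 70%, meaning an expected step of a number 6 percentage points higher from compound 3 to compound 4 (within the scatter).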

Compound 4, a percentage reported as inhibition, at one concentration (the size of the read-out at that concentration, not a potency): > 80%
Compound 4 gave a limit, no number (the forecaster's own chance of this, stated with the estimate: 10%); middle value at least 40 percentage points away from the limit.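

Measured in this assay the exchange of anilino for (4-hydroxybutyl)amino gives a number at least 46 percentage points higher from compound 3 to compound 4 (beyond the scatter) and shows that the group on this nitrogen strongly affects inhibition. An aromatic ring here is not needed for high inhibition, since an open chain ending in a hydroxyl also gives it. As far as these compounds go, compound 4 gives only the limit > 80% and the full size of the step stays unknown: the limit of > 80% in this assay, at which 2 of the 4 values shown sit.

A plain butyl chain would help separate the effect of losing the phenyl from that of adding the hydroxyl. From the compounds shown here alone, whether a shorter chain or a terminal amine does as well also remains open.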